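This account rests on a few compounds, and the source may have more. Where it says the series, first, only, none or still open, it means among the compounds named here.

Three compounds share one core and were measured in a functional assay on PC-3 cells (Homo sapiens) for inhibition, read by sulforhodamine B assay, with a stated time of 48 h; a lower number here means a stronger inhibitor of growth, a higher number a weaker inhibitor of growth:

Compound 1 `CCOC(=O)C1=C(C)NC(=S)NC1c1ccc(O)cc1`: 47.6 ug/mL
Compound 2 `CCOC(=O)C1=C(C)NC(=S)NC1c1ccc(O)c(O)c1`: 25 ug/mL
Compound 3 `CCOC(=O)C1=C(C)NC(=S)NC1c1cccc(OC)c1`: 10.2 ug/mL

Compound 3 stands lowest of the three. Compound 2 gives 25 ug/mL and compound 1 gives 47.6 ug/mL, both higher than compound 3, and beyond the scatter in each case.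

Compound 4 `CCOC(=O)C1=C(C)NC(=S)NC1c1ccc(O)c(OC)c1` differs from compound 3 by hydroxy in place of hydrogen on an aromatic carbon. Within the data shown here, one measured step bears on this change: a 1.9-fold lower number from compound 1 to compound 2 (0.28 log units; within the scatter), where a hydroxy entered a ring already carrying a hydroxy. That step stayed within the scatter, so for compound 4 a step of about a 1.1-fold lower number from compound 3 to compound 4 (0.05 log units; within the scatter) in this assay is expected, not beyond the scatter. Compound 4 is therefore estimated at 9 ug/mL, with a range from 4 ug/mL to 22 ug/mL.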

Compound 4, concentration for 50% growth inhibition: 72.6 ug/mL
Compound 4: middle estimate off by 8.1-fold (0.91 log units), on the low side, and the stated range ends below it.
By their numbers in this assay, from the lowest: compound 3; then compounds 2, 1 and 4 (each within the scatter of the next, the first and the last beyond it).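

In this assay the hydroxy entering ortho to a methoxy group gives a 7.1-fold higher number from compound 3 to compound 4 (0.85 log units; beyond the scatter) and the change does not carry over from one core to the other: the same change on two cores in this assay, a 1.9-fold lower number (0.28 log units; within the scatter) from compound 1 to compound 2 and a 7.1-fold higher number (0.85 log units; beyond the scatter) from compound 3 to compound 4, 14-fold (1.13 log units) apart, beyond the scatter of two such steps.

Methyl in place of hydrogen on the oxygen gives a 2.9-fold higher number from compound 2 to compound 4 (0.46 log units; beyond the scatter) while a methoxy entering the aromatic ring gives a 1.5-fold higher number from compound 1 to compound 4 (0.18 log units; within the scatter) and so stays level with compound 1.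

Still open, as far as these compounds go, is whether an amine or a carboxylic acid at this position, or a longer chain in place of the methyl on the oxygen, would keep the low number of compound 3.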